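Exchanging the Ring on the Sulfonamide Nitrogen

A few compounds are considered here, and "the series" means these few. Any claim that something is new, unique, unknown or untested is made for them only; others in the source may bear on it.

Of the compounds shown here, three built on a shared core have been tested in a functional assay on LoVo cells (Homo sapiens) for antiproliferative activity, read by sulforhodamine B assay, with a stated time of 48 h; a higher number here means a weaker inhibitor, a lower number a stronger inhibitor. Compound 1 `Nc1ccc(S(=O)(=O)Nc2ccnc3cc(C(F)(F)F)ccc23)cc1` gives 53700 nM. Compound 2 `Cc1noc(NS(=O)(=O)c2ccc(N/C(S)=N\c3ccnc4cc(C(F)(F)F)ccc34)cc2)c1C` gives 67100 nM, and compound 3 `O=S(=O)(Nc1nccs1)c1ccc(N/C(S)=N\c2ccnc3cc(C(F)(F)F)ccc23)cc1` gives 67100 nM. Among the compounds with values here, the one step measured between neighbours, no change at the digits printed from compound 2 to compound 3 (within the scatter), shows that exchanging the 3,4-dimethyl-1,2-oxazol-5-yl group for 1,3-thiazol-2-yl on the sulfonamide nitrogen left the number where it was. Compound 3 thus stands level with compound 2 at the digits printed, the two together being the highest of the three numbers, while compound 1 lies within the scatter of both.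

Compound 4 `Cc1cc(C)nc(NS(=O)(=O)c2ccc(N/C(S)=N\c3ccnc4cc(C(F)(F)F)ccc34)cc2)n1` carries the change (4,6-dimethylpyrimidin-2-yl in place of 1,3-thiazol-2-yl on a sulfonamide nitrogen). Within the data shown here, the only measured step that bears on this change is no change at the digits printed from compound 2 to compound 3 (within the scatter), which also swapped one ring for another on the same sulfonamide nitrogen and produced nothing beyond the scatter. Among the measured compounds shown here, no measured pair distinguishes a six-membered ring from a five-membered one at this position, so there is no ground for predicting a shift in either direction. Compound 4 is therefore expected to show a step of no change at the digits printed from compound 3 to compound 4 (within the scatter) in this assay, that is, no change beyond the scatter. For compound 4 the estimated value is 67100 nM, with a range from 40000 nM to 110000 nM.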

Compound 4, half-maximal inhibitory concentration: 40200 nM
The estimate for compound 4 lay 1.7-fold (0.22 log units) above the measured number; low and high end bracket the measured number.
By their numbers in this assay, from the lowest: compounds 4, 1, 2 and 3 (each within the scatter of the next).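

In this assay, placing 4,6-dimethylpyrimidin-2-yl on the sulfonamide nitrogen gives a 1.7-fold lower number from compound 3 to compound 4 (0.22 log units; within the scatter) when it replaces 1,3-thiazol-2-yl, and a 1.7-fold lower number from compound 2 to compound 4 (0.22 log units; within the scatter) when it replaces 3,4-dimethyl-1,2-oxazol-5-yl. Compounds 2, 3 and 4 therefore extend the earlier single exchange to a comparison of three rings, and the six-membered aromatic ring with its two methyl groups stays within the scatter of both five-membered rings, with none of the three compounds going against this. No measurement is available that would account for the numbers at this position.

All three groups compared on this nitrogen are aromatic rings, so the compounds shown leave open how a saturated ring such as piperidine, an open chain such as n-butyl or a group bearing a carboxylic acid would read in this assay. Within the data shown here, they also leave open whether a ring carrying an amine instead of methyl groups would move the number beyond the scatter, since compound 4 is the only six-membered example here.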